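From hydroxy to amino on a short chain

The compounds below may be only part of what the source reports. "The series", "measured", "known", "first", "only" and "open" are said of these compounds alone.

In a functional assay on HCT-116 cells (Homo sapiens) for cytotoxicity, read by MTT assay, with a stated time of 72 h (a lower number here means a stronger inhibitor, a higher number a weaker inhibitor), compound 3 `O=C(NCc1ccc(F)cc1)c1nc(Br)c2cccnc2c1NCCO` gives > 20000 nM, which is a limit and not a number. Compound 1 `Nc1cccc(Nc2c(C(=O)NCc3ccc(F)cc3)nc(Br)c3cccnc23)c1` also gives only a limit, > 10000 nM. Compound 2 `Nc1ccc(Nc2c(C(=O)NCc3ccc(F)cc3)nc(Br)c3cccnc23)cc1` is the only one of the three with a true number, 7000 nM.

Compound 4 `NCCNc1c(C(=O)NCc2ccc(F)cc2)nc(Br)c2cccnc12` differs from compound 3 in one place, with amino in place of hydroxy on a saturated chain carbon, two bonds along the chain from a nitrogen on an aromatic ring. The 2-hydroxyethyl group thus becomes 2-aminoethyl.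

For the measured compounds named here, no measured step makes this exact exchange, and those at the same nitrogen bear on it only loosely. The clearest is an at least 2.8-fold higher number from compound 2 to compound 3 (0.45 log units; beyond the scatter). The other two are an at least 1.4-fold lower number from compound 1 to compound 2 (0.15 log units; that floor lies within the scatter) and a step that the two limits leave unreadable from compound 1 to compound 3. Both compounds with an aminophenyl group keep an amino group, yet only compound 2 reached a number, so compound 1 goes against any simple link between that group and a measurable value.

A modest move towards a lower number in this assay is therefore expected, though another limit would be no surprise. The expected change is an at least 1.6-fold lower number from compound 3 to compound 4 (0.22 log units; that floor lies within the scatter). For compound 4 the estimate is 12000 nM, with an expected range from 3500 nM to 30000 nM.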

Compound 4, half-maximal inhibitory concentration: > 20000 nM
Compound 4: only a limit was reported (the forecaster's own chance of this, stated with the estimate: 40%); middle value at least 1.6-fold (0.22 log units) away from the limit.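

Amino in place of hydroxy on the short chain brings no true number: in this assay, the 2-aminoethyl group leaves compound 4 at a limit, as the 2-hydroxyethyl group leaves compound 3. The exchange of 4-aminophenyl for 2-aminoethyl gives an at least 2.8-fold higher number from compound 2 to compound 4 (0.45 log units; beyond the scatter), so an amino group on a short chain does not reproduce the measurable value seen with 4-aminophenyl, and compound 1, with 3-aminophenyl and only a limit, shows that an aminophenyl group does not ensure such a value either. The new steps that end at compound 4 and start from compound 1 or compound 3 cannot be read, because both ends of each are limits: the limit of > 20000 nM in this assay, at which 2 of the 4 values shown sit.

Going by these compounds, whether the hydroxy and amino compounds differ at all beyond that limit stays open. On these data alone, it is also open what a longer chain such as 3-aminopropyl, or a carboxylic acid in place of the amino group, would give in this assay.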